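SCD1 inhibitors: aryl ether variation on the piperidine oxygen

The compounds below may be only part of what the source reports. "The series", "measured", "known", "first", "only" and "open" are said of these compounds alone.

Measured compounds in an assay on microsomes from liver for inhibition of acyl-CoA desaturase 1 (Rattus norvegicus); a lower number here means a stronger inhibitor, a higher number a weaker inhibitor:
- compound 1 `c1cc2c(c(OC3CCN(c4ccc(-n5ccnc5)nn4)CC3)c1)CCC2`: 10 nM
- compound 2 `Brc1cccc(OC2CCN(c3ccc(-n4ccnc4)nn3)CC2)c1`: 23 nM

Within the data shown here, compound 2 gives the higher of the two numbers so far; the only step, a 2.3-fold higher number from compound 1 to compound 2 (0.36 log units; beyond the scatter), lies beyond the scatter and was modest. Compound 3 `COc1ccccc1OC1CCN(c2ccc(-n3ccnc3)nn2)CC1` carries the change 2-methoxyphenyl in place of 3-bromophenyl on an oxygen on a saturated carbon on the shared core of compound 2. Among the measured compounds shown here, only one measured step bears on this position: a 2.3-fold higher number from compound 1 to compound 2 (0.36 log units; beyond the scatter), which shows that exchanging the aryl group at this oxygen shifts the number modestly without a large swing. For the measured compounds named here, no measured pair shows a methoxy group on that aryl ring, so direction here cannot be read from the data; a shift of similar size in either direction is plausible. Compound 3 is therefore expected to stay within a modest step, estimated as a 1.3-fold higher number from compound 2 to compound 3 (0.12 log units; within the scatter). The estimate for compound 3 in this assay is 30 nM, with a range from 10 nM to 90 nM.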

Compound 3, half-maximal inhibitory concentration: 543 nM
Estimate against measurement, compound 3: 18-fold (1.26 log units) below, outside the stated range (above it).
By their numbers in this assay, from the lowest: compound 1; then compound 2; then compound 3.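

The aryl group on this oxygen can move the number far more than the first pair suggested: in this assay the earlier exchange was only a 2.3-fold higher number from compound 1 to compound 2 (0.36 log units; beyond the scatter) and was modest, whereas 2-methoxyphenyl gives a 24-fold higher number from compound 2 to compound 3 (1.37 log units; beyond the scatter) and also a 54-fold higher number from compound 1 to compound 3 (1.73 log units; beyond the scatter) with both steps large. Both of the other aryl groups give clearly lower numbers than 2-methoxyphenyl, so this position does not tolerate every aryl exchange equally. No measured data bearing on the origin of this loss are available here.

The change from 3-bromophenyl replaces the substituent and alters where it sits on the ring in one step, and the compounds shown do not separate these two contributions. As far as these compounds go, how an amine or a carboxylic acid on this aryl ring would behave also remains open.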